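A few compounds are considered here, and "the series" means these few. Any claim that something is new, unique, unknown or untested is made for them only; others in the source may bear on it.

Measured compounds in a functional assay on NCI-H226 cells (Homo sapiens) for inhibition, read by MTT assay, with a stated time of 48 h, tested at 10 uM; on this read-out higher numbers stand for more inhibition at the one concentration tested (going by the name of the read-out) and lower numbers for less inhibition:
- compound 1 `COc1ccc(F)cc1Nc1cc(NC(=O)Nc2c(Cl)cccc2Cl)ncn1`: 31.3%
- compound 2 `Cc1cc(F)cc(Nc2cc(NC(=O)Nc3c(Cl)cccc3Cl)ncn2)c1`: 78.1%
- compound 3 `COc1cc(NC(=O)Nc2cc(Nc3ccc(C)c(F)c3)ncn2)cc(OC)c1`: 39.7%

Compound 2 holds the highest number of the three; compound 3 sits well under it, and compound 1 lower still, both gaps beyond the scatter.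

Compound 4 `COc1ccc(Nc2cc(NC(=O)Nc3c(Cl)cccc3Cl)ncn2)cc1C` is not yet measured. Its change from compound 2 is 4-methoxy-3-methylphenyl in place of 3-fluoro-5-methylphenyl on a nitrogen on an aromatic ring.

Within the data shown here, the only measured step touching the same nitrogen is a number 46.8 percentage points higher from compound 1 to compound 2 (beyond the scatter), where the methoxy-bearing aryl gave the lower number. Compound 4 again carries a methoxy-bearing aryl at that nitrogen, so a step downward in this assay is expected, of a size comparable to that one, though the pattern rests on a single pair.

Compound 4 is therefore estimated at 45%, range 25% to 70%, which means an expected step of a number 33.1 percentage points lower from compound 2 to compound 4 (beyond the scatter).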

Compound 4, a percentage reported as inhibition, at one concentration (the size of the read-out at that concentration, not a potency): 50%
Compound 4: the middle estimate sits 5 percentage points below what was measured; low and high end bracket the measured number.
By their numbers in this assay, from the lowest: compounds 1 and 3 (each within the scatter of the next); then compound 4; then compound 2.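

In this assay, the aryl group on this nitrogen gives a graded scale, not a simple split: 4-methoxy-3-methylphenyl gives a number 28.1 percentage points lower from compound 2 to compound 4 (beyond the scatter) and also a number 18.7 percentage points higher from compound 1 to compound 4 (beyond the scatter). Both methoxy-bearing aryl groups stay under 3-fluoro-5-methylphenyl, yet they also differ from each other, so the presence of a methoxy group alone does not fix the number. Nothing at hand explains these differences. Going by these compounds, since the step from compound 2 to compound 4 changes several substituents together, the share of each remains open. So does the outcome with an amine or a carboxylic acid on this aryl ring.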